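The source may report more compounds than this note shows. Statements on the series, on what has been measured and on what is new or still open speak of the compounds shown alone.

Measured so far:
compound 2 `Nc1nc(N)nc(-c2ccc(Cl)cc2Cl)n1` — 100%
compound 1 `COc1ccccc1-c1nc(N)nc(N)n1` — 1%

In a functional assay on the whole organism with Rattus norvegicus as the target, at a dose of 20 mg/kg by the intraperitoneal route (a lower number here means less inhibition, a higher number more inhibition at the dose given (going by the name of the read-out)), compound 2 gives 100%, the higher of the two numbers, and compound 1 gives 1%, a gap beyond the scatter. Among the compounds with values here, the two differ in more than one place, so no single step is known between them.

Compound 3 `Nc1nc(N)nc(-c2ccccc2Cl)n1` differs from compound 2 by hydrogen in place of chloro on an aromatic carbon. Loss of one chloro is expected to lower inhibition, probably by a moderate amount, though the full drop to the level of compound 1 seems unlikely. For compound 3 the estimated value in this assay is 55%, range 10% to 100%. The estimate implies a downward step a number 45 percentage points lower from compound 2 to compound 3 (beyond the scatter).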

Compound 3, a percentage reported as inhibition, in the whole organism at one dose (the size of the read-out at that dose, not a potency) in the Rattus norvegicus assay: 36%
For compound 3 the middle estimate is 19 percentage points above the measured one; the measured number falls inside the stated range.
By their numbers in the Rattus norvegicus assay, from the lowest: compound 1; then compound 3; then compound 2.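

Chloro at this position, para to a group of 8 heavy atoms, carries much of the inhibition in the Rattus norvegicus assay, with hydrogen in its place giving a number 64 percentage points lower from compound 2 to compound 3 (beyond the scatter). The chloro that remains in compound 3 still keeps part of it, with chloro in place of methoxy giving a number 35 percentage points higher from compound 1 to compound 3 (beyond the scatter). In a physicochemical assay for lipophilicity (on this read-out higher numbers stand for higher lipophilicity and lower numbers for lower lipophilicity), compound 2 gives 2.07 and compound 3 gives 1.19, so the loss of inhibition goes with lower lipophilicity: the measured partition coefficient of compound 2, 2.07, and of compound 3, 1.19, a number 0.88 log units lower (beyond the scatter).

The compounds shown leave open whether inhibition follows lipophilicity or depends on the chloro itself. A methyl group or an amine at this position would bear on that.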